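The source may report more compounds than this note shows. Statements on the series, on what has been measured and on what is new or still open speak of the compounds shown alone.

In a functional assay on HL-60 cells (Homo sapiens) for inhibition, read by resazurin assay, with a stated time of 72 h (on this read-out lower numbers stand for stronger inhibition and higher numbers for weaker inhibition), compound 1 `COc1ccc(C2C(O)C(=O)N2c2cc(OC)c(OC)c(OC)c2)cc1` gives 13 nM while compound 2 `CCSc1ccc(C2C(Oc3ccccc3)C(=O)N2c2cc(OC)c(OC)c(OC)c2)cc1` gives 508 nM as the higher of the two numbers, a gap well beyond the scatter. Compound 3 `COc1ccc(C2C(Oc3ccccc3)C(=O)N2c2cc(OC)c(OC)c(OC)c2)cc1` is still unmeasured. It follows from compound 2 by methoxy in place of ethylsulfanyl on an aromatic carbon with methoxy in place of ethylsulfanyl on an aromatic carbon, para to a large group. Among the measured compounds shown here, no measured pair isolates this change, so the expectation rests only on the lower number of compound 1 at 13 nM as a guide. The expected step in this assay is a 4.2-fold lower number from compound 2 to compound 3 (0.63 log units; beyond the scatter) toward stronger inhibition. For compound 3 the expected value is 120 nM with 30 nM to 450 nM as the estimated range.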

Compound 3, half-maximal inhibitory concentration: 19 nM
Compound 3: the middle estimate sits 6.3-fold (0.80 log units) above what was measured; the measured number lies below the stated range.
By their numbers in this assay, from the lowest: compounds 1 and 3 (each within the scatter of the next); then compound 2.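

In this assay the exchange of ethylsulfanyl for methoxy, para to a large group on the aromatic ring, gives a 27-fold lower number from compound 2 to compound 3 (1.43 log units; beyond the scatter) and so isolates a large effect at this position. Phenyl in place of the hydrogen on the oxygen gives a 1.5-fold higher number from compound 1 to compound 3 (0.16 log units; within the scatter) when methoxy is present, so this exchange costs nothing measurable here. Nothing available explains the size of the first step.

From the compounds shown here alone, it remains open whether a hydroxyl, an amine or a longer alkoxy chain at this position would match methoxy. Going by these compounds, it also remains open whether ethylsulfanyl would behave the same with the free hydroxyl group.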